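Hydrazone partners on a shared thiazole-free core, compared

A few compounds are considered here, and "the series" means these few. Any claim that something is new, unique, unknown or untested is made for them only; others in the source may bear on it.

Measured so far:
compound 1 `COc1cccc(-c2csc(N/N=C/c3cccc4ccccc34)n2)c1`: 3640 nM
compound 2 `CCCCCC/C(C)=N/Nc1nc(-c2cccc(OC)c2)cs1`: 1380 nM

Both compounds were tested in an assay on isolated protein for inhibition of Amine oxidase [flavin-containing] A (Homo sapiens), read by fluorescence; a lower number here means a stronger inhibitor, a higher number a weaker inhibitor. Compound 2 has the lower of the two numbers: its value sits well below that of compound 1, and the gap between them is larger than the usual scatter of repeated measurements, so compound 2 is the stronger inhibitor of this pair.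

Compound 3 `COc1cccc(-c2csc(N/N=C(\C)c3ccncc3)n2)c1` has not yet been measured in this assay. It differs from compound 2 in one place: pyridin-4-yl in place of hexyl on a carbon with a double bond to nitrogen. A flexible chain is thus exchanged for an aromatic ring carrying one hydrogen-bond acceptor.

Within the data shown here, with only two measured compounds and no pair that differs in a single place, the direction of this exchange cannot be read from the data. Compound 1, which also carries an aromatic group at that carbon, gives the weaker value, so a somewhat weaker result is expected for compound 3, with a step of a 2.2-fold higher number from compound 2 to compound 3 (0.34 log units; beyond the scatter). Compound 3 is estimated at 3000 nM, within a range from 800 nM to 12000 nM.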

Compound 3, half-maximal inhibitory concentration: 3710 nM
Estimate against measurement, compound 3: 1.2-fold (0.09 log units) below; the measured number falls inside the stated range.
By their numbers in this assay, from the lowest: compound 2; then compounds 1 and 3 (each within the scatter of the next).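

Among these compounds, this is the first pair that differs in only one place, so the effect of this change can be read directly. In this assay, putting pyridin-4-yl in place of hexyl on a carbon with a double bond to nitrogen gives a 2.7-fold higher number from compound 2 to compound 3 (0.43 log units; beyond the scatter), a modest loss of inhibition. Both groups have the same count of heavy atoms, so the step reflects an open chain giving way to an aromatic ring with a hydrogen-bond acceptor, and no measurement shown explains it.

From the compounds shown here alone, whether the loss follows from the ring itself or from its nitrogen stays open, and a phenyl group at this carbon would separate the two. A butyl or an octyl chain there would show how much the length of the chain matters.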